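Chloro in Place of Fluoro on Compound 3

The compounds below may be only part of what the source reports. "The series", "measured", "known", "first", "only" and "open" are said of these compounds alone.

Of the compounds shown here, three have been measured. Compound 1 `COc1ccc(CNc2cc(OC)c(OC)c(OC)c2)cc1Cl` gives 46200 nM in a functional assay on MGC-803 cells (Homo sapiens) for inhibition, read by MTT assay, with a stated time of 48 h; a lower number here means a stronger inhibitor, a higher number a weaker inhibitor. Compound 2 `COc1ccc(CNc2cc(OC)c(OC)c(OC)c2)cc1F` gives 39700 nM in this assay. Compound 3 `C/C=C/C(=O)N(Cc1ccc(OC)c(F)c1)c1cc(OC)c(OC)c(OC)c1` gives 1650 nM in this assay.

Two steps connect these. From compound 2 to compound 1 the change is chloro in place of fluoro on an aromatic carbon, and it gives a 1.2-fold higher number from compound 2 to compound 1 (0.07 log units; within the scatter). From compound 2 to compound 3 the change is (prop-1-en-1-yl)carbonyl in place of hydrogen on a nitrogen on an aromatic ring, and it gives a 24-fold lower number from compound 2 to compound 3 (1.38 log units; beyond the scatter). Compound 3 thus stands at the lowest number of the three, with both other compounds beyond the scatter from it.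

Compound 4 `C/C=C/C(=O)N(Cc1ccc(OC)c(Cl)c1)c1cc(OC)c(OC)c(OC)c1` has not yet been measured. It differs from compound 3 by chloro in place of fluoro on an aromatic carbon, the same change that carries compound 2 to compound 1, at the same place. The cores on which the change is made differ by (prop-1-en-1-yl)carbonyl in place of hydrogen on a nitrogen on an aromatic ring. The earlier step was within the scatter, so the step from compound 3 to compound 4 is expected to be small, about a 1.2-fold higher number from compound 3 to compound 4 (0.06 log units; within the scatter), because a 1.2-fold higher number from compound 2 to compound 1 (0.07 log units; within the scatter). Compound 4 is therefore estimated at 1900 nM, expected to fall between 800 nM and 4500 nM.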

Compound 4, half-maximal inhibitory concentration: 7100 nM
Beside the measured number, compound 4's estimate is 3.7-fold (0.57 log units) below it; measured number above the stated range.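

In this assay, chloro in place of fluoro gives a 4.3-fold higher number from compound 3 to compound 4 (0.63 log units; beyond the scatter), and this step does not carry over unchanged from the core of compound 2: the same change on two cores in this assay, a 1.2-fold higher number (0.07 log units; within the scatter) from compound 2 to compound 1 and a 4.3-fold higher number (0.63 log units; beyond the scatter) from compound 3 to compound 4, 3.7-fold (0.57 log units) apart, beyond the scatter of two such steps

Read the other way, (prop-1-en-1-yl)carbonyl in place of hydrogen on the nitrogen gives a 6.5-fold lower number from compound 1 to compound 4 (0.81 log units; beyond the scatter), so the lower number persists on the chloro compounds, but the step is smaller than on the fluoro compounds: the same change on two cores in this assay, a 24-fold lower number (1.38 log units; beyond the scatter) from compound 2 to compound 3 and a 6.5-fold lower number (0.81 log units; beyond the scatter) from compound 1 to compound 4, 3.7-fold (0.57 log units) apart, beyond the scatter of two such steps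

These two gaps come from the same four compounds and are a single observation, so they show that the outcome of the halogen change depends on the core here, but not why it does or how far this holds beyond these two cores.

The compounds shown leave open whether the same dependence on the core appears with bromo, methyl or a nitrile in place of the fluoro group. They also leave open whether it persists when an acetyl or a butanoyl group replaces the (prop-1-en-1-yl)carbonyl group.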